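A few compounds are considered here, and "the series" means these few. Any claim that something is new, unique, unknown or untested is made for them only; others in the source may bear on it.

Measured compounds in a functional assay on MCF7 cells (Homo sapiens) for cytotoxicity, read by MTT assay, with a stated time of 72 h; on this read-out higher numbers stand for weaker inhibition and lower numbers for stronger inhibition:
Compound 1, `COc1cccc(/C=C2\CCC/C(=C\c3ccc(O)cc3)C2=O)c1OC`, gives > 20000 nM, a limit of the assay rather than a number.
Compound 2, `COc1cc(/C=C2\CCC/C(=C\c3cccc(OC)c3OC)C2=O)cc(OC)c1`, gives 1700 nM.
Compound 3, `COc1ccc(/C=C2\CCC/C(=C\c3ccc(Br)cc3)C2=O)cc1OC`, gives 6900 nM.

Among the two values that are numbers, compound 3 stands highest; the nearest is compound 2, whose number is lower by a margin beyond the usual scatter. Compound 1 sits at the limit of this assay (the limit of > 20000 nM in this assay, at which 1 of the 3 values shown sits).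

The step to compound 4, `COc1ccc(/C=C2\CCC/C(=C\c3ccc(O)c(O)c3)C2=O)cc1OC`, changes one group: 3,4-dihydroxyphenyl in place of 4-bromophenyl on a double-bonded chain carbon bound to a double-bonded ring carbon. For the measured compounds named here, no step between measured compounds shares this change, so its size must be judged from the three values alone. Compound 1, which also bears hydroxyl groups, returned only the limit in this assay (the limit of > 20000 nM in this assay, at which 1 of the 3 values shown sits), whereas compound 2 and compound 3, which carry none, gave numbers. On that basis compound 4 is expected to be weaker than compound 3, by a step of a 2.2-fold higher number from compound 3 to compound 4 (0.34 log units; beyond the scatter) toward a higher number. The estimate for compound 4 is 15000 nM, with a range from 5000 nM to 40000 nM, and a real chance that this assay reports only a limit.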

Compound 4, half-maximal inhibitory concentration: 14400 nM
Compound 4: the middle estimate sits 1.0-fold (0.02 log units) above what was measured; the range from low to high includes it.
By their numbers in this assay, from the lowest: compound 2; then compound 3; then compound 4. At a limit, above all of these: compound 1.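

In this assay, for the compounds shown here, this is the first step read at this position on the chain carbon: a 2.1-fold higher number from compound 3 to compound 4 (0.32 log units; beyond the scatter), a modest change. It shows that exchanging 4-bromophenyl for 3,4-dihydroxyphenyl on an otherwise unchanged compound costs some inhibition but does not abolish it, and compound 4 still returns a number rather than a limit. Compound 1, which differs from compound 4 in more than one place, remains a limit of the assay and cannot be set against this step: the limit of > 20000 nM in this assay, at which 1 of the 4 values shown sits.

Going by these compounds alone, the single step removes bromine and adds two hydroxyl groups at once, so it cannot say which of the two accounts for the shift. From the compounds shown here alone, whether an amine or a carboxylic acid on that ring would give a stronger or weaker number remains open.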